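The source may hold more compounds than are shown below. What is called first, only, known or untested is meant among the compounds shown, and "the series" means these compounds.

Compound 1 `C#CCOC(=O)C[C@@H]1C(C(=O)OC)=CO[C@@H](O[C@@H]2O[C@H](CO)[C@@H](O)[C@H](O)[C@H]2O)/C1=C/C` gives > 15000 nM. Compound 2 `C=CCOC(=O)C[C@@H]1C(C(=O)OC)=CO[C@@H](O[C@@H]2O[C@H](COC(C)=O)[C@@H](OC(C)=O)[C@H](OC(C)=O)[C@H]2OC(C)=O)/C1=C/C` gives > 20000 nM. Compound 3 `C/C=C1/[C@H](O[C@@H]2O[C@H](COC(C)=O)[C@@H](OC(C)=O)[C@H](OC(C)=O)[C@H]2OC(C)=O)OC=C(C(=O)O)[C@H]1CC(=O)OCCCCCCCCCCCCCCC` gives > 20000 nM.

All three values come from a functional assay on SK-BR-3 cells (Homo sapiens) for antiproliferative activity, read by MTT assay, with a stated time of 72 h (a higher number here means a weaker inhibitor, a lower number a stronger inhibitor), and every one of them is a limit of the assay rather than a number. Compound 1 sits at the limit of > 15000 nM in this assay, at which 1 of the 3 values shown sits. The two other compounds sit at the limit of > 20000 nM in this assay, at which 2 of the 3 values shown sit. Among the measured compounds shown here, no pair of measured compounds differs in a single place, so nothing measured here shows how one change moves potency. Compound 4 `C/C=C1/[C@H](O[C@@H]2O[C@H](CO)[C@@H](O)[C@H](O)[C@H]2O)OC=C(C(=O)OC)[C@H]1CC(=O)OCc1ccco1` differs from compound 1 in one place: furan-2-yl in place of ethynyl on a saturated chain carbon bound to an oxygen next to a carbonyl group. Because compound 1 gives > 15000 nM in this assay, a limit, the step that the limit leaves unreadable from compound 1 to compound 4 is expected to be nothing beyond the scatter. Compound 4 is estimated at 20000 nM, between 8000 nM and 60000 nM, most likely reported as a limit again.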

Compound 4, half-maximal inhibitory concentration: > 15000 nM
Compound 4: only a limit was reported (the forecaster's own chance of this, stated with the estimate: 80%); the middle value lies beyond the limit too.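

Compound 1 and compound 4 are both reported only as limits of the assay, so the step between them cannot be read: the limit of > 15000 nM in this assay, at which 2 of the 4 values shown sit.

What stays open is whether any compound shown has a measurable potency in this assay.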